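The compounds below may be only part of what the source reports. "The series", "measured", "known", "first", "only" and "open" are said of these compounds alone.

Series notes. Compound 1 `Cc1ccc(S(=O)(=O)c2nc3ccccc3nc2Nc2cccc(O)c2)cc1`, compound 2 `Cc1ccc(S(=O)(=O)c2nc3ccccc3nc2Nc2ccc(F)cc2)cc1` and compound 3 `O=S(=O)(c1ccc(Br)cc1)c1nc2ccccc2nc1Nc1cccc(O)c1` have been run in a functional assay on A549 cells (Homo sapiens) for cytotoxicity, read by MTT assay, with a stated time of 72 h; on this read-out lower numbers stand for stronger inhibition and higher numbers for weaker inhibition; compound 4 `O=S(=O)(c1ccc(Br)cc1)c1nc2ccccc2nc1Nc1ccc(F)cc1` has not. In this assay compound 1 gives 6080 nM. In this assay compound 2 gives 39200 nM. In this assay compound 3 gives 8000 nM.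

The change from compound 1 to compound 2 is 4-fluorophenyl in place of 3-hydroxyphenyl on a nitrogen on an aromatic ring and it produced a 6.4-fold higher number from compound 1 to compound 2 (0.81 log units; beyond the scatter). The two cores differ by bromo in place of methyl on an aromatic carbon, with a 1.3-fold higher number from compound 1 to compound 3 (0.12 log units; within the scatter), so compound 1 and compound 3 cannot be told apart on this read-out.

Compound 4 stands to compound 3 as compound 2 stands to compound 1: the change is 4-fluorophenyl in place of 3-hydroxyphenyl on a nitrogen on an aromatic ring, the same change at the same place, seen once so far among measured pairs.

Among the measured compounds shown here, a weakening step of about the same size is expected from compound 3 to compound 4 in this assay, estimated as a 6.0-fold higher number from compound 3 to compound 4 (0.78 log units; beyond the scatter), because the one measured example of this change gave a 6.4-fold higher number from compound 1 to compound 2 (0.81 log units; beyond the scatter) and the cores themselves gave no step of note. The estimate rests on a single pair, so the range is kept wide. Compound 4 is expected to give about 48000 nM, between 20000 nM and 120000 nM. Measurement pending.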

Compound 4, half-maximal inhibitory concentration: 4360 nM
Beside the measured number, compound 4's estimate is 11-fold (1.04 log units) above it; measured number below the stated range.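

In this assay, 4-fluorophenyl in place of 3-hydroxyphenyl on the nitrogen does not carry from the core of compound 1 to the core of compound 3, where the step reads a 1.8-fold lower number from compound 3 to compound 4 (0.26 log units; within the scatter), and the two steps differ: the same change on two cores in this assay, a 6.4-fold higher number (0.81 log units; beyond the scatter) from compound 1 to compound 2 and a 1.8-fold lower number (0.26 log units; within the scatter) from compound 3 to compound 4, 12-fold (1.07 log units) apart, beyond the scatter of two such steps. Bromo in place of methyl likewise depends on the group on the nitrogen, with a 9.0-fold lower number from compound 2 to compound 4 (0.95 log units; beyond the scatter) in the 4-fluorophenyl pair, against no step of note in the 3-hydroxyphenyl pair: the same change on two cores in this assay, a 1.3-fold higher number (0.12 log units; within the scatter) from compound 1 to compound 3 and a 9.0-fold lower number (0.95 log units; beyond the scatter) from compound 2 to compound 4, 12-fold (1.07 log units) apart, beyond the scatter of two such steps. These four compounds therefore show that the two changes do not add up in this series, but they do not show why, and with one square of compounds they cannot show how general this is.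

Open, as far as these compounds go, is whether the dependence persists with an amine or a methoxy group on the phenyl ring on the nitrogen in place of the hydroxy or fluoro group. Also open, from the compounds shown here alone, is whether chloro or methoxy on the aromatic carbon that carries methyl or bromo sides with the methyl core or the bromo core.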